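This account rests on a few compounds, and the source may have more. Where it says the series, first, only, none or still open, it means among the compounds named here.

Compound 3 `CCOC(=O)CCCCCOc1cccc(CN(C(=O)c2ccc(-c3cccc(-c4nnc(C)o4)c3)cc2)C(C)C)c1` is measured in an ADME assay on HEK293 cells (Homo sapiens) for cytotoxicity, read by CellTiter-Glo and resazurin assay, with a stated time of 72 h; a higher number here means that more compound is needed for the effect, a lower number that less compound is needed. In this assay compound 3 gives > 26000 nM, which is a limit of the assay rather than a number. Compound 1 `Cc1nnc(-c2cccc(-c3ccc(C(=O)N(Cc4cccc(OCCCCCC(=O)O)c4)C(C)C)cc3)c2)o1` gives > 26000 nM in this assay, again only a limit. Compound 2 `CC(C)N(Cc1cccc(OCCCCCC(=O)O)c1)C(=O)c1ccc(-c2cccc(Cl)c2)cc1` gives > 21900 nM, also a limit. Compound 3 therefore stands with the other two at the edge of what this assay can report, since two of the three values sit at the limit of > 26000 nM in this assay, at which 2 of the 3 values shown sit, and one at the limit of > 21900 nM in this assay, at which 1 of the 3 values shown sits. Compound 4 `CCOC(=O)CCCCCOc1cccc(CN(C(=O)c2ccc(-c3cccc(CC(=O)O)c3)cc2)C(C)C)c1` differs from compound 3 by carboxymethyl in place of 5-methyl-1,3,4-oxadiazol-2-yl on an aromatic carbon. Within the data shown here, two measured steps touch related compounds: the step from compound 1 to compound 2 is a step that the two limits leave unreadable from compound 1 to compound 2, and the step from compound 1 to compound 3 is a step that the two limits leave unreadable from compound 1 to compound 3, so neither shows a readable size. Among the measured compounds shown here, none of the measured steps changes the group that differs between compound 3 and compound 4. The expected step is a number no higher from compound 3 to compound 4 (the limit leaves the size open), none beyond the scatter. Compound 4 is estimated at 26000 nM in this assay, between 10000 nM and 80000 nM, most likely again only a limit.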

Compound 4, half-maximal effective concentration: > 26000 nM
Compound 4 gave a limit, no number (the forecaster's own chance of this, stated with the estimate: 85%); the middle value sits exactly at the limit.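

Compound 3 and compound 4 each give only a limit, so the swap of 5-methyl-1,3,4-oxadiazol-2-yl for carboxymethyl cannot be read as a step of any size. The compounds shown leave open what concentration of any of them would reach the half-maximal effect in this assay.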